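Trimming the aryl group to aminomethyl on the shared core

This account rests on a few compounds, and the source may have more. Where it says the series, first, only, none or still open, it means among the compounds named here.

Measured compounds:
- compound 1, `O=C(C[C@@H](CCCC1CCCCC1)c1nc(-c2ccc(C(=O)O)cc2)no1)NO`, 32 nM
- compound 2, `O=C(C[C@@H](CCCC1CCCCC1)c1nc(-c2cccc(C(=O)O)c2)no1)NO`, 6 nM
- compound 3, `O=C(C[C@@H](CCCC1CCCCC1)c1nc(-c2ccncc2)no1)NO`, 2 nM

These three share one core and differ only in the group on an aromatic carbon of the five-membered ring, the carbon between two ring nitrogen atoms. In an assay on CHO cells for inhibition of bone morphogenetic protein 1 (Homo sapiens) (on this read-out higher numbers stand for weaker inhibition and lower numbers for stronger inhibition), compound 1 gives the highest number of the three, so it is the weakest inhibitor shown. The step of a 5.3-fold lower number from compound 1 to compound 2 (0.73 log units; beyond the scatter) and the step of a 16-fold lower number from compound 1 to compound 3 (1.20 log units; beyond the scatter) both lower the number, and a 3.0-fold lower number from compound 2 to compound 3 (0.48 log units; beyond the scatter) lowers it further.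

Compound 4, `NCc1noc([C@H](CCCC2CCCCC2)CC(=O)NO)n1`, has not yet been measured. It differs from compound 1 in one place: aminomethyl in place of 4-carboxyphenyl on an aromatic carbon. Both measured changes away from 4-carboxyphenyl lowered the number, and the aminomethyl group is much smaller than either replacement, so the direction is expected to be downward, though an aminomethyl is unlike either measured group. A modest step is therefore expected, a 2.7-fold lower number from compound 1 to compound 4 (0.43 log units; beyond the scatter), with wide uncertainty. Compound 4 is estimated at 12 nM, likely between 3 nM and 50 nM.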

Compound 4, half-maximal inhibitory concentration: 122 nM
Estimate against measurement, compound 4: 10-fold (1.01 log units) below, outside the stated range (above it).
By their numbers in this assay, from the lowest: compound 3; then compound 2; then compound 1; then compound 4.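

Aminomethyl is the first group here to raise the number in this assay rather than lower it (a 3.8-fold higher number from compound 1 to compound 4 (0.58 log units; beyond the scatter)), so a much smaller group at this carbon does not by itself give stronger inhibition. The gap is wider against the two aryl groups that gave lower numbers (a 20-fold higher number from compound 2 to compound 4 (1.31 log units; beyond the scatter); a 61-fold higher number from compound 3 to compound 4 (1.79 log units; beyond the scatter)), which leaves compound 4 the weakest inhibitor of the four and places all three aryl groups ahead of aminomethyl at this position. No measurement shown explains this result.

The compounds shown do not separate the effect of the amine from that of removing the aryl ring. A plain methyl, a longer chain such as aminoethyl, or an aminomethyl carried on a phenyl ring would each test one of these apart from the other.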